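Three Limits and a Chloro Analog Awaiting Measurement

This account rests on a few compounds, and the source may have more. Where it says the series, first, only, none or still open, it means among the compounds named here.

Compound 1, `CC#CCn1c(N2CCC[C@@H](N)C2)nc2c1c(=O)n(Cc1c(Br)cccc1C(=O)O)c(=O)n2C`, in an ADME assay on isolated protein for inhibition of Dipeptidyl peptidase 9 (Homo sapiens), with stated times of 15 min, 60 s and 20 min (a higher number here means a weaker inhibitor, a lower number a stronger inhibitor), gives > 100000 nM, a limit of the assay.
Compound 2, `CC#CCn1c(N2CCC[C@@H](N)C2)nc2c1c(=O)n(Cc1cc(Cl)ccc1C(=O)O)c(=O)n2C`, in this assay gives > 100000 nM, a limit of the assay.
Compound 3, `CC#CCn1c(N2CCC[C@@H](N)C2)nc2c1c(=O)n(Cc1cc(OC)ccc1C(=O)O)c(=O)n2C`, in this assay gives > 100000 nM, a limit of the assay.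

All three measured compounds share one core and differ only in the substituted benzoic acid carried on the saturated chain carbon bound to an aromatic nitrogen. Compound 3 stands at the limit of the assay, as do the other two, so no one of them can be placed above or below another. The steps between them are accordingly unreadable: a step that the two limits leave unreadable from compound 1 to compound 2, a step that the two limits leave unreadable from compound 1 to compound 3 and a step that the two limits leave unreadable from compound 2 to compound 3. Within the data shown here, the one piece of evidence is the limit of > 100000 nM in this assay, at which 3 of the 3 values shown sit.

Compound 4, `CC#CCn1c(N2CCC[C@@H](N)C2)nc2c1c(=O)n(Cc1c(Cl)cccc1C(=O)O)c(=O)n2C`, has not yet been measured. It differs from compound 3 in that (2-carboxy-6-chlorophenyl in place of 2-carboxy-5-methoxyphenyl on a saturated chain carbon bound to an aromatic nitrogen). The measured steps that bear on this change are the three unreadable ones above, none of which reports a size, so no direction can be drawn from them. Among the measured compounds shown here, because every compound so far sits at the limit of > 100000 nM in this assay, at which 3 of the 3 values shown sit, compound 4 is expected to sit there too, with a step that the limit leaves unreadable from compound 3 to compound 4 as the expected step. The estimate for compound 4 is 150000 nM, ranging from 50000 nM to 500000 nM.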

Compound 4, half-maximal inhibitory concentration: > 100000 nM
Compound 4 ended at the assay's limit; the forecaster's own chance of this, stated with the estimate: 90%; the middle value lies beyond the limit too.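

Compound 4, like compound 1, compound 2 and compound 3, sits at a limit in this assay, so none of the steps among these four compounds can be read. The compounds shown leave open how strongly any of them inhibits the enzyme and whether changing the substituted benzoic acid alters this at all, with only one finding in hand: the limit of > 100000 nM in this assay, at which 4 of the 4 values shown sit.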